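Moving the chlorine on the aryl group of compound 2

The compounds below may be only part of what the source reports. "The series", "measured", "known", "first", "only" and "open" are said of these compounds alone.

compound 1 `Cc1cccc(C2CC(c3ccc(Oc4ccccc4)cc3)=NN2c2ccc(S(N)(=O)=O)cc2)c1`: 8000 nM
compound 2 `NS(=O)(=O)c1ccc(N2N=C(c3ccc(Oc4ccccc4)cc3)CC2c2ccccc2Cl)cc1`: 8000 nM

In an ADME assay on BHK-21 cells (Mesocricetus auratus) for cytotoxicity, read by MTT assay, with a stated time of 72 h (a higher number here means that more compound is tolerated, a lower number that less compound is tolerated), compound 2 gives 8000 nM, level with compound 1 at the digits shown. The next compound to be measured is compound 3 `NS(=O)(=O)c1ccc(N2N=C(c3ccc(Oc4ccccc4)cc3)CC2c2cccc(Cl)c2)cc1`, which has the same atoms as compound 2, joined differently: 3-chlorophenyl in place of 2-chlorophenyl on a saturated ring carbon. It carries 3-chlorophenyl in place of 2-chlorophenyl on a saturated ring carbon. Among the compounds with values here, only one measured step bears on this change, no change at the digits printed from compound 1 to compound 2 (within the scatter), where 2-chlorophenyl replaced 3-methylphenyl at that same carbon. Within the data shown here, no measured compound yet carries 3-chlorophenyl, so this single step is thin support. Even so, no shift in either direction beyond the scatter is expected in this assay. The estimated outcome is no change at the digits printed from compound 2 to compound 3 (within the scatter). Compound 3 is expected at 8000 nM, with an estimated range of 4000 nM to 16000 nM.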

Compound 3, half-maximal cytotoxic concentration: 9000 nM
For compound 3 the middle estimate is 1.1-fold (0.05 log units) below the measured one, within the range that was stated.
By their numbers in this assay, from the lowest: compounds 1, 2 and 3 (each within the scatter of the next).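

In this assay, moving the chlorine on the aryl group at the saturated ring carbon gives a 1.1-fold higher number from compound 2 to compound 3 (0.05 log units; within the scatter), so the 2-chlorophenyl and 3-chlorophenyl groups cannot be told apart in this read-out. Chloro in place of methyl on an aromatic carbon gives a 1.1-fold higher number from compound 1 to compound 3 (0.05 log units; within the scatter), so this swap on the aryl group also stays within the scatter. Nothing available accounts for these values.

All three compounds carry a single chloro or methyl group on the aryl ring at this carbon, which leaves the effect of other kinds of group there unresolved. From the compounds shown here alone, whether an amine or a carboxylic acid on that ring, or a change to the 4-sulfamoylphenyl group, would move the number beyond the scatter stays open.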